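Working notes: nitro in place of bromo

This account rests on a few compounds, and the source may have more. Where it says the series, first, only, none or still open, it means among the compounds named here.

Compound 1 `O=Cc1cn(Cc2cccc(C(F)(F)F)c2)c2ccccc12`: 1780 nM
Compound 2 `OCc1cn(Cc2ccc(Cl)cc2)c2ccccc12`: 79 nM
Compound 3 `OCc1cn(Cc2ccc(Br)cc2)c2ccccc12`: 390 nM

Going by the values given here, in a functional assay on T29Kt1 cells (Homo sapiens) for cytotoxicity, read by sulforhodamine B assay, with a stated time of 3 days (a higher number here means a weaker inhibitor, a lower number a stronger inhibitor), compound 3 at 390 nM stands between compound 2 and compound 1 on the numbers so far. Compound 4 `O=[N+]([O-])c1ccc(Cn2cc(CO)c3ccccc32)cc1` has nitro in place of bromo on an aromatic carbon, para to a large group (nitro in place of bromo on an aromatic carbon). Among the compounds with values here, the one measured step at this place is a 4.9-fold higher number from compound 2 to compound 3 (0.69 log units; beyond the scatter) and it is modest, but it shows nothing about nitro. A step of no greater size is therefore expected in this assay with no firm direction. The expected step is a 1.3-fold lower number from compound 3 to compound 4 (0.11 log units; within the scatter) on the middle estimate. For compound 4 the estimate is 300 nM with an expected range from 70 nM as lower end to 1300 nM as upper end.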

Compound 4, half-maximal inhibitory concentration: 150 nM
Compound 4: the middle estimate sits 2.0-fold (0.30 log units) above what was measured; low and high end bracket the measured number.
By their numbers in this assay, from the lowest: compounds 2 and 4 (each within the scatter of the next); then compound 3; then compound 1.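

In this assay this aromatic carbon, para to a large group, also tolerates a group other than a halogen: nitro in place of bromo gives a 2.6-fold lower number from compound 3 to compound 4 (0.41 log units; beyond the scatter). Nitro in place of chloro gives a 1.9-fold higher number from compound 2 to compound 4 (0.28 log units; within the scatter), so nitro and chloro cannot be told apart here, and among these three compounds only bromo stands apart. No measurement at hand explains either step. Open, on these data alone, is how an amine or a carboxylic acid on this same carbon would read in this assay.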